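Removing Two Methyl Groups from a Pyrazole Hydroquinone Ether

The source may report more compounds than this note shows. Statements on the series, on what has been measured and on what is new or still open speak of the compounds shown alone.

Measured compounds:
Compound 1, `COc1ccc(OC)c(-c2cc(-c3ccc(Cl)cc3)nn2-c2ccccc2)c1`, gives 84300 nM in a functional assay on cells (Cancer cell lines, Homo sapiens) for cytotoxicity, read by sulforhodamine B assay, with a stated time of 48 h; a higher number here means a weaker inhibitor of growth, a lower number a stronger inhibitor of growth.
Compound 2, `COc1ccc(OC)c(-c2cc(-c3ccc(Cl)cc3)nn2-c2ccc(S(=O)(=O)NC(C)=O)cc2)c1`, gives 50000 nM in this assay.

For the measured compounds named here, compound 2 stands at the lower of the two numbers obtained so far; the one step recorded, a 1.7-fold lower number from compound 1 to compound 2 (0.23 log units; within the scatter), stays within the scatter, so the two compounds cannot be told apart on these data.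

Compound 3, `CC(=O)NS(=O)(=O)c1ccc(-n2nc(-c3ccc(Cl)cc3)cc2-c2cc(O)ccc2O)cc1`, differs from compound 2 in one place: 2,5-dihydroxyphenyl in place of 2,5-dimethoxyphenyl on an aromatic carbon. The 2,5-dihydroxyphenyl sits on an aromatic carbon of the five-membered aromatic ring with two nitrogens, next to the ring nitrogen and next to the ring atom that bears a large group.

Going by the values given here, no measured step touches this part of the molecule. Among the compounds with values here, the only recorded step concerns the acetylsulfamoyl group on a different ring and was itself within the scatter. There is therefore nothing in the data that predicts a change in this assay for compound 3 beyond the scatter, in either direction.

On that basis compound 3 is expected to give about 45000 nM, within a range from 15000 nM to 130000 nM, a step of a 1.1-fold lower number from compound 2 to compound 3 (0.05 log units; within the scatter) that is estimated to remain within the scatter.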

Compound 3, concentration for total growth inhibition: 93900 nM
For compound 3 the middle estimate is 2.1-fold (0.32 log units) below the measured one; the range from low to high includes it.
By their numbers in this assay, from the lowest: compounds 2, 1 and 3 (each within the scatter of the next).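

In this assay, the first change made at this position, 2,5-dihydroxyphenyl in place of 2,5-dimethoxyphenyl on an aromatic carbon of the five-membered ring, gives a 1.9-fold higher number from compound 2 to compound 3 (0.27 log units; within the scatter). The swap removes two methyl groups and adds hydrogen-bond donors, yet the step cannot be told apart from repeat-to-repeat variation, so these two compounds show no measurable response to it in this read-out. No accompanying measurement bears on this result, and the data offer no explanation for it.

As far as these compounds go, this is a single pair, and it carries the acetylsulfamoyl group, so it remains unknown whether the same swap would behave alike on compound 1, which has a hydrogen in that place. From the compounds shown here alone, it also remains open whether a longer chain on those oxygens, such as ethoxy, or a phenyl ring bearing an amine or a carboxylic acid at this position, would move the number beyond the scatter.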